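Aryl sulfone series: working notes on microsome clearance

The compounds below may be only part of what the source reports. "The series", "measured", "known", "first", "only" and "open" are said of these compounds alone.

All numbers below come from an ADME assay on microsomes from liver (Homo sapiens) for metabolic stability, tested at 2.5 uM; a higher number here means faster removal of the compound, a lower number slower removal.

Compound 1 `O=S(=O)(c1ccc(F)c(Cl)c1)c1cnc2c(F)cccc2c1-c1ccccc1F`: 1.39 mL/min
Compound 2 `O=S(=O)(c1cccc(F)c1)c1cnc2c(F)cccc2c1-c1ccccc1F`: 0.21 mL/min
Compound 3 `O=S(=O)(c1ccc(F)c(F)c1)c1cnc2c(F)cccc2c1-c1ccccc1F`: 1.39 mL/min

Compound 2 stands lowest of the three in this assay: the step of a 6.6-fold lower number from compound 1 to compound 2 (0.82 log units; beyond the scatter) and the step of a 6.6-fold higher number from compound 2 to compound 3 (0.82 log units; beyond the scatter) both lie beyond the scatter, while between compound 1 and compound 3 there is no change at the digits printed from compound 1 to compound 3 (within the scatter). For the measured compounds named here, every measured step so far concerns the group on the sulfonyl sulfur only.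

Compound 4 `O=S(=O)(c1cccc(F)c1)c1cnc2c(F)cccc2c1-c1ccc(F)cc1` differs from compound 2 at another site: 4-fluorophenyl in place of 2-fluorophenyl on an aromatic carbon. Going by the values given here, no measured pair varies this part of the molecule, so the three known steps give no direct guide; the shared core and the sulfonyl group are kept, and the group on the sulfonyl sulfur is the same 3-fluorophenyl as in compound 2. In the absence of a bearing step, the expectation for compound 4 in this assay is a step of a 1.4-fold higher number from compound 2 to compound 4 (0.15 log units; within the scatter), within the scatter. Compound 4 is therefore estimated at 0.3 mL/min, with a range from 0.1 mL/min to 0.9 mL/min.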

Compound 4, intrinsic clearance in a liver preparation (reported as CLH), per the amount of preparation that the assay uses: 0.19 mL/min
The estimate for compound 4 lay 1.6-fold (0.20 log units) above the measured number; the range from low to high includes it.
By their numbers in this assay, from the lowest: compounds 4 and 2 (each within the scatter of the next); then compounds 1 and 3 (each within the scatter of the next).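

With 4-fluorophenyl in place of 2-fluorophenyl on the aromatic carbon of the core, this assay gives a 1.1-fold lower number from compound 2 to compound 4 (0.04 log units; within the scatter) and so does not separate the two compounds. This is the first reading at this position, and with 3-fluorophenyl on the sulfonyl sulfur, the two fluorophenyl groups shown here are not told apart, whereas a single added fluoro on the sulfonyl aryl group gives a 6.6-fold higher number from compound 2 to compound 3 (0.82 log units; beyond the scatter) in the same read-out. No measurement at hand accounts for either result.

The compounds shown leave open whether this position stays as indifferent with 3-chloro-4-fluorophenyl on the sulfonyl sulfur, as in compound 1. Also open, as far as these compounds go, is what a group other than a fluorophenyl at this position, such as a pyridyl ring, an amine or a carboxylic acid, would give.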